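Para-substituent swap on the diaryl urea series

This account rests on a few compounds, and the source may have more. Where it says the series, first, only, none or still open, it means among the compounds named here.

Measured so far:
compound 1 `COC(=O)c1ccc(NC(=O)N[C@H]2CC[C@H](Oc3ccc(F)cc3)CC2)cc1` — 11600 nM
compound 2 `O=C(Nc1cccc(C(F)(F)F)c1)N[C@H]1CC[C@H](Oc2cccc(F)c2)CC1` — 2400 nM
compound 3 `O=C(Nc1cccc(C(F)(F)F)c1)N[C@H]1CC[C@@H](Oc2ccc(F)cc2)CC1` — 2600 nM

Of the compounds shown here, three of the shared core have been read in a functional assay on CRL2813 cells (Homo sapiens) for cytotoxicity, read by sulforhodamine B assay, with a stated time of 5 days; on this read-out higher numbers stand for weaker inhibition and lower numbers for stronger inhibition. Compound 1 gives 11600 nM, the highest number of the three. Compound 3 gives 2600 nM and compound 2 gives 2400 nM; both stand below compound 1 by margins beyond the scatter, while the two of them lie within the scatter of each other and are not ordered. Compound 1 is thus the weakest of the set in this assay. Going by the values given here, compound 2 and compound 3 carry a trifluoromethyl on the aryl urea side and differ from compound 1 in more than one place, so no single step is attributed to any one change.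

The next compound, compound 4 `Cc1ccc(NC(=O)N[C@H]2CC[C@H](Oc3ccc(F)cc3)CC2)cc1`, is still unmeasured in this assay. It differs from compound 1 in one place: methyl in place of methoxycarbonyl on an aromatic carbon. The change is methyl in place of methoxycarbonyl on an aromatic carbon, para to a large group. Among the compounds with values here, no measured pair isolates this change, so the direction rests on the set as a whole. Compound 1 sits at the weak end, and the two other aryl patterns give lower numbers, so some gain is plausible but not assured. Compound 4 is expected to show a step of a 1.9-fold lower number from compound 1 to compound 4 (0.29 log units; within the scatter), a modest move toward stronger inhibition. The estimate for compound 4 is 6000 nM, with a range from 2000 nM to 18000 nM.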

Compound 4, half-maximal inhibitory concentration: > 20000 nM
Compound 4: only a limit was reported (the forecaster's own chance of this, stated with the estimate: 5%); middle value at least 3.3-fold (0.52 log units) away from the limit.
By their numbers in this assay, from the lowest: compounds 2 and 3 (each within the scatter of the next); then compound 1. At a limit, above all of these: compound 4.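

Going by these compounds alone, this pair is the first comparison that differs in one place, and it isolates the group on an aromatic carbon, para to a large group, which the earlier compounds could not do. In this assay, methyl in place of methoxycarbonyl gives an at least 1.7-fold higher number from compound 1 to compound 4 (0.23 log units; that floor lies within the scatter), so this swap brings no lower number, and the step has only a floor, with its full size unread. Compound 4 stands at a limit of the assay, which is not a number: the limit of > 20000 nM in this assay, at which 1 of the 4 values shown sits.

This single pair cannot separate the hydrogen-bond acceptors that leave with methoxycarbonyl from the other heavy atoms that leave with it, and it cannot say whether the number for compound 1 depends on either. A carboxylic acid, a primary amide or a nitrile on the same aromatic carbon of the shared core would bear on that question, and a measured value for compound 4 from a wider concentration range would give the step an actual size.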